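The source may report more compounds than this note shows. Statements on the series, on what has been measured and on what is new or still open speak of the compounds shown alone.

Among the compounds with values here, compound 1 `O=C(O)CCn1c(=O)oc2cc(OCC3CCC3)c(Cl)cc21` was measured in an assay on HEK293 cells for inhibition of kynurenine 3-monooxygenase (Homo sapiens), read by LC-MS, with a stated time of 20 h (a lower number here means a stronger inhibitor, a higher number a weaker inhibitor), and gives 1260 nM, the higher of the two numbers known here. Within the data shown here, the other measured compound, compound 2 `Cc1ccc([C@@H](C)Oc2cc3onc(CCC(=O)O)c3cc2Cl)nn1`, gives 3.16 nM in this assay, a much lower number, but it is built on a different core and shares no single-point step with compound 1, so the two values say nothing about any one change. The unmeasured compound 3 `COc1cc2oc(=O)n(CCC(=O)O)c2cc1Cl` differs from compound 1 by hydrogen in place of cyclobutyl on a saturated chain carbon bound to an oxygen on an aromatic ring; cut one bond further out, the same change reads as cyclobutylmethoxy going to methoxy. Among the measured compounds shown here, no measured pair shows what this change does. With the cyclobutyl gone, compound 3 is expected to be the weaker inhibitor, by a step of a 4.0-fold higher number from compound 1 to compound 3 (0.60 log units; beyond the scatter) in this assay, beyond the usual scatter but not large. Compound 3 is therefore estimated at 5000 nM, with a range from 1500 nM to 20000 nM.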

Compound 3, half-maximal inhibitory concentration: 5010 nM
The estimate for compound 3 lay 1.0-fold (0.00 log units) below the measured number, and the stated range covers the measured number.
By their numbers in this assay, from the lowest: compound 2; then compound 1; then compound 3.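

Within the data shown here, compound 3 gives the first reading of a single change at this place: in this assay, hydrogen in place of cyclobutyl on a saturated chain carbon bound to an oxygen on an aromatic ring brings a 4.0-fold higher number from compound 1 to compound 3 (0.60 log units; beyond the scatter), a modest step. Cutting cyclobutylmethoxy back to methoxy thus weakens inhibition in this assay, yet the number for compound 3 shows that inhibition on this core does not depend entirely on the cyclobutyl. No measurement at hand accounts for this step.

The compounds shown leave open whether the number follows the size of the group, since nothing lies between methoxy and cyclobutylmethoxy, and neither ethoxy nor the larger cyclopentylmethoxy appears. Among these compounds, they also leave open whether the same change would act alike on the core of compound 2, which no single-place step links to compound 1 or compound 3.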